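From compound 2 to compound 4: a longer side chain

This account rests on a few compounds, and the source may have more. Where it says the series, first, only, none or still open, it means among the compounds named here.

In a functional assay on HCT-116 cells (Homo sapiens) for cytotoxicity, read by MTT assay (a higher number here means a weaker inhibitor, a lower number a stronger inhibitor), compound 2 `Cc1c(O)cc(CCCC(C)C)oc1=O` gives > 200000 nM as a limit of the assay, not a number. Compound 1 `COc1cc(CCCCC(C)(C)O)oc(=O)c1C` gives > 200000 nM and this too is a limit. Compound 3 `CCC(C)CCCCc1cc(O)c(C)c(=O)o1` gives > 200000 nM and this is also a limit. Every measured compound therefore rests on the limit of > 200000 nM in this assay, at which 3 of the 3 values shown sit, and none has a readable potency.

Compound 4 `Cc1c(O)cc(CCCCC(C)[C@H](C)O)oc1=O` changes the side chain of compound 2, with 3-hydroxy-2-methylbutyl in place of isopropyl, and 3-hydroxy-2-methylbutyl in place of isopropyl on a saturated chain carbon, three bonds along the chain from an aromatic carbon gives the count of what leaves and enters.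

The nearest measured change is 2-methylbutyl in place of isopropyl at that same place, which is a step that the two limits leave unreadable from compound 2 to compound 3 and so gives no size to build on. With no readable step, and with all three compounds at the limit in this assay, the likeliest result is another limit. The expected change is a number no higher from compound 2 to compound 4 (the limit leaves the size open) and no step beyond the scatter is expected in either direction. For compound 4 the estimated value is 200000 nM with an expected range from 80000 nM to 400000 nM at its upper end.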

Compound 4, half-maximal inhibitory concentration: > 200000 nM
Compound 4: only a limit was reported (the forecaster's own chance of this, stated with the estimate: 80%); the middle value sits exactly at the limit.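

The steps from compound 2 to compound 4 and from compound 3 to compound 4 cannot be read, since these compounds all rest on one limit: the limit of > 200000 nM in this assay, at which 4 of the 4 values shown sit.

The compounds shown leave open whether any of these side chains gives a readable potency in this assay, and how such potencies would compare.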